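The source may hold more compounds than are shown below. What is called first, only, known or untested is meant among the compounds shown, and "the series" means these compounds.

Series notes. Compound 1 `CCN(CC)c1cc(C)c2cc(NC(=O)c3ccc(Cl)c(Cl)c3)ccc2n1` carries a diethylamino group on the shared core. In a functional assay on MCF7 cells (Homo sapiens) for antiproliferative activity, read by MTT assay, with a stated time of 72 h (a lower number here means a stronger inhibitor, a higher number a weaker inhibitor), compound 1 gives only a limit, > 50000 nM, so its standing on the numbers shown is known no closer than that limit (the limit of > 50000 nM in this assay, at which 1 of the 2 values shown sits). Compound 2 `CCN1CCN(c2cc(C)c3cc(NC(=O)c4ccc(F)c(F)c4)ccc3n2)CC1` differs from compound 1 in more than one place; in this assay compound 2 gives 5230 nM. Among the measured compounds shown here, no single-point step connects compound 1 and compound 2, so their two values are simply set side by side: one a limit, the other a measured number within the working range. Compound 3 `Cc1cc(N2CCN(C(C)C)CC2)nc2ccc(NC(=O)c3ccc(Cl)c(Cl)c3)cc12` is the next entry: 4-isopropylpiperazin-1-yl in place of diethylamino on an aromatic carbon. For the measured compounds named here, no measured step of this kind exists in the set. The expectation is a gain in potency, beyond the scatter, on going to compound 3, resting on compound 2, which gives 5230 nM with a related ring amine in the same place. The estimate for compound 3 is 8000 nM, with a range from 2000 nM to 40000 nM. The estimated step is an at least 6.2-fold lower number from compound 1 to compound 3 (0.79 log units; beyond the scatter). A limit read-out remains possible.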

Compound 3, half-maximal inhibitory concentration: 1710 nM
Compound 3: the middle estimate sits 4.7-fold (0.67 log units) above what was measured, and the stated range ends above it.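

In this assay, 4-isopropylpiperazin-1-yl in place of diethylamino on the aromatic carbon next to the ring nitrogen gives an at least 29-fold lower number from compound 1 to compound 3 (1.46 log units; beyond the scatter). Among the compounds shown here, this is the first change made in one place only, and it shows that the amine at this position can by itself move the series from a limit read-out to a measured value, with the rest of the molecule held constant. The true size of the step remains unknown because the value for compound 1 is a limit and not a number: the limit of > 50000 nM in this assay, at which 1 of the 3 values shown sits.

The change brings a six-membered non-aromatic ring, more nitrogen and an isopropyl group all at once, so the part of 4-isopropylpiperazin-1-yl that accounts for the step stays open; piperidin-1-yl, morpholin-4-yl or a piperazine bearing methyl in place of isopropyl at the same carbon would begin to separate these features. Compound 2 differs from compound 3 in more than one place, so the pair cannot show how ethyl and isopropyl on the piperazine compare, or how the halogens on the benzamide ring compare.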